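Swapping methylsulfanyl for fluoro on a quinoline urea

This account rests on a few compounds, and the source may have more. Where it says the series, first, only, none or still open, it means among the compounds named here.

Three urea compounds share one core, and all were tested in an ADME assay on BJ cells (Homo sapiens) for cytotoxicity, with a stated time of 72 h; on this read-out lower numbers stand for an effect already at smaller amounts and higher numbers for an effect only at larger amounts of compound. Compound 1, `CCc1ccc(NC(=O)Nc2cc(C)nc3ccccc23)cc1`, gives > 25000 nM, a limit of the assay and not a number. Compound 2, `Cc1cc(NC(=O)Nc2cc(F)cc(F)c2)c2ccccc2n1`, gives > 25000 nM, again only a limit. Compound 3, `CSc1ccccc1NC(=O)Nc1cc(C)nc2ccccc12`, gives > 25000 nM, which is likewise a limit rather than a measured number. So compound 3 stands where every compound so far stands: at the limit of > 25000 nM in this assay, at which 3 of the 3 values shown sit, with no cytotoxic effect seen within the tested range.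

Compound 4, `Cc1cc(NC(=O)Nc2ccccc2F)c2ccccc2n1`, differs from compound 3 in one place: fluoro in place of methylsulfanyl on an aromatic carbon. The fluoro sits on an aromatic carbon of a six-membered aromatic ring of carbon only, ortho to a large group.

No measured step exists between any two of these compounds, so nothing shows how such a change shifts this assay. Given that compound 3 gives > 25000 nM, the step from compound 3 to compound 4 is expected to be none beyond the scatter. Compound 4 is therefore expected to give 40000 nM, between 20000 nM and 100000 nM, most likely reported again only as a limit. In this assay the step that the limit leaves unreadable from compound 3 to compound 4 is the expected outcome.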

Compound 4, half-maximal effective concentration: > 25000 nM
Compound 4 ended at the assay's limit; the forecaster's own chance of this, stated with the estimate: 85%; the middle value does not contradict the limit.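

Compound 3 and compound 4 both give a limit of the assay rather than a measured number, so the step of fluoro in place of methylsulfanyl between them cannot be read: the limit of > 25000 nM in this assay, at which 4 of the 4 values shown sit. The compounds shown leave open whether any change to the shared core brings cytotoxicity into the tested range.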